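The source may hold more compounds than are shown below. What is called first, only, known or untested is meant among the compounds shown, and "the series" means these compounds.

The series shares one core, with the aryl group on the carbonyl carbon varied. In a toxicity assay on WI-38 cells (Homo sapiens) for cytotoxicity, read by MTT assay, with a stated time of 48 h (on this read-out lower numbers stand for stronger inhibition and higher numbers for weaker inhibition), compound 1 `O=C(/C=C/c1ccc2c(c1)B(O)OC2)c1ccccc1` gives 19100 nM. Compound 2 `O=C(/C=C/c1ccc2c(c1)B(O)OC2)c1cccnc1` gives 76200 nM, a step of a 4.0-fold higher number from compound 1 to compound 2 (0.60 log units; beyond the scatter). Compound 3 `O=C(/C=C/c1ccc2c(c1)B(O)OC2)c1ccc(O)cc1` reaches only the limit (the limit of > 100000 nM in this assay, at which 1 of the 3 values shown sits), and its value > 100000 nM is a limit of the assay and not a number. The step of an at least 5.2-fold higher number from compound 1 to compound 3 (0.71 log units; beyond the scatter) lies beyond the scatter, while an at least 1.3-fold higher number from compound 2 to compound 3 (0.11 log units; that floor lies within the scatter) has a floor within it. Compound 4 `O=C(/C=C/c1ccc2c(c1)B(O)OC2)c1cccc(O)c1` differs from compound 3 by 3-hydroxyphenyl in place of 4-hydroxyphenyl on a carbonyl carbon. Going by the values given here, no measured step swaps one hydroxyphenyl for another; the only step involving a hydroxy group, an at least 5.2-fold higher number from compound 1 to compound 3 (0.71 log units; beyond the scatter), ran toward weaker inhibition, so no step beyond the scatter is expected in this assay. Compound 4 is therefore estimated at 100000 nM, within 40000 nM to 300000 nM, a step of a number no higher from compound 3 to compound 4 (the limit leaves the size open) expected to stay within the scatter.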

Compound 4, half-maximal inhibitory concentration: 26400 nM
Compound 4: middle estimate off by 3.8-fold (0.58 log units), on the high side; measured number below the stated range.
By their numbers in this assay, from the lowest: compounds 1 and 4 (each within the scatter of the next); then compound 2. At a limit, above all of these: compound 3.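

In this assay the placing of the hydroxy group counts, with the same atoms joined differently: an at least 3.7-fold lower number from compound 3 to compound 4 (0.57 log units; beyond the scatter). The value of compound 3 is a limit and not a number: the limit of > 100000 nM in this assay, at which 1 of the 4 values shown sits A hydroxy group on the phenyl therefore does not by itself go with weaker inhibition, since for 3-hydroxyphenyl the step is a 1.4-fold higher number from compound 1 to compound 4 (0.14 log units; within the scatter), and against the pyridin-3-yl it is a 2.9-fold lower number from compound 2 to compound 4 (0.46 log units; beyond the scatter).

Still open, from the compounds shown here alone, is how a methoxyphenyl or an aminophenyl on the carbonyl carbon would read here. Going by these compounds, the true size of the gap between the two hydroxyphenyl compounds also stays open.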